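Extending the Ring-Amine Substituent from Ethyl to Pentyl

The source may hold more compounds than are shown below. What is called first, only, known or untested is meant among the compounds shown, and "the series" means these compounds.

Of the compounds shown here, three have so far been measured in a functional assay on HEK293 cells for activation of 5-hydroxytryptamine receptor 4 (Homo sapiens), read by cAMP accumulation; a higher number here means a larger maximal response, a lower number a smaller maximal response. Compound 1 `COc1cc(N)c(Cl)cc1C(=O)NC1CCNCC1` returns a reading that is a limit of the assay rather than a number, > 100%. Compound 2 `COc1ccc2[nH]cc(C(=O)NC3CCNCC3)c2c1`, built on a different core, gives 0% in this assay. Compound 3 `CCN1CCC(NC(=O)c2cc(Cl)c(N)cc2OC)CC1` likewise returns a limit of the assay, > 100%. The step that the two limits leave unreadable from compound 1 to compound 3 cannot be read in size because both of its ends sit at the limit of > 100% in this assay, at which 2 of the 3 values shown sit.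

Compound 4 `CCCCCN1CCC(NC(=O)c2cc(Cl)c(N)cc2OC)CC1` differs from compound 3 by propyl in place of hydrogen on a saturated chain carbon, two bonds along the chain from an amine nitrogen in a ring. For the measured compounds named here, no measured step speaks to a change of this kind on the ring-amine chain, so the only anchor is that compound 3 already stands at the top of what this assay can report. Compound 4 is therefore expected to remain a strong activator, estimated at 100% with a range from 80% to 110%. The step of a number no higher from compound 3 to compound 4 (the limit leaves the size open) is expected to stay within the usual scatter.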

Compound 4, intrinsic activity: the largest response reached, in percent of the reference agonist's: > 100%
Compound 4 ended at the assay's limit (the forecaster's own chance of this, stated with the estimate: 45%); the middle value sits exactly at the limit.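

For the compounds shown here, no step to compound 4 can be read in this assay, neither from compound 1 nor from compound 3, because all three compounds sit at the same limit of the assay: the limit of > 100% in this assay, at which 3 of the 4 values shown sit.

On these data alone, how the maximal responses of compound 1, compound 3 and compound 4 truly compare stays open.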